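Replacing the Benzylamine Linker with an Arylthioether

A few compounds are considered here, and "the series" means these few. Any claim that something is new, unique, unknown or untested is made for them only; others in the source may bear on it.

Compound 3 `Nc1cc(N)c2nc(-c3ccccc3)c(NCc3ccc(F)cc3)nc2c1` gives 1820 nM in a functional assay on SF-539 cells (Homo sapiens) for inhibition, read by sulforhodamine B assay, with a stated time of 48 h (a higher number here means a weaker inhibitor of growth, a lower number a stronger inhibitor of growth), the lowest number among the three measured compounds. Compound 1 `Nc1cc(N)c2nc(-c3ccccc3)c(NCc3ccc(Cl)c(Cl)c3)nc2c1` gives 4570 nM, and a 2.5-fold lower number from compound 1 to compound 3 (0.40 log units; beyond the scatter). Compound 2 `CCOC(=O)[C@H](CCC(=O)O)NC(=O)c1ccc(Oc2nc3cc(N)cc(N)c3nc2-c2ccccc2)cc1`, which bears an aryl ether rather than a benzylamine, gives 33900 nM. Compound 4 `Nc1cc(N)c2nc(-c3ccccc3)c(Sc3ccc(F)cc3)nc2c1` differs from compound 3 by (4-fluorophenyl)sulfanyl in place of (4-fluorobenzyl)amino on an aromatic carbon. For the measured compounds named here, the single measured step concerns the substituents on the benzyl ring, not the linker itself, so it does not bear directly on this change; compound 2 shows only that an oxygen-linked aryl group carrying a large appendage gives a much higher number. The step is therefore expected to be a 2.5-fold higher number from compound 3 to compound 4 (0.39 log units; beyond the scatter), upward and uncertain. Compound 4 is estimated at 4500 nM, within 1200 nM to 20000 nM.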

Compound 4, concentration for 50% growth inhibition: 21400 nM
Beside the measured number, compound 4's estimate is 4.8-fold (0.68 log units) below it, and the stated range ends below it.
By their numbers in this assay, from the lowest: compound 3; then compound 1; then compounds 4 and 2 (each within the scatter of the next).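

In this assay the link at this aromatic carbon weighs far more than the ring substituents did: the change gives a 12-fold higher number from compound 3 to compound 4 (1.07 log units; beyond the scatter) and so outruns a 2.5-fold lower number from compound 1 to compound 3 (0.40 log units; beyond the scatter) by a wide margin. The entering (4-fluorophenyl)sulfanyl group loses the nitrogen, its hydrogen-bond donor and the chain carbon together, so this one step cannot tell these changes apart. No measurement shown explains the higher number. Still open, on these data alone, is whether the sulfur or the missing chain carbon matters more, which a (4-fluorophenyl)amino or a (4-fluorobenzyl)sulfanyl group at this carbon would separate.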